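The source may report more compounds than this note shows. Statements on the series, on what has been measured and on what is new or still open speak of the compounds shown alone.

In a functional assay on HeLa cells (Homo sapiens) for inhibition, read by CCK-8 assay, with a stated time of 72 h (a higher number here means a weaker inhibitor, a lower number a stronger inhibitor), compound 1 `O=C(/C=C/c1cccnc1)NCCCCCCCc1cccc(S(=O)(=O)Nc2ccccc2)c1` gives 598 nM, compound 2 `Cc1ccc(NS(=O)(=O)c2cccc(CCCCCCNC(=O)/C=C/c3cccnc3)c2)cc1` gives 38.8 nM and compound 3 `Cc1cccc(NS(=O)(=O)c2cccc(CCCCCCNC(=O)/C=C/c3cccnc3)c2)c1` gives 65.8 nM. Compound 3 sits within the scatter of compound 2, and both give clearly lower numbers than compound 1, which differs from them in more than one place. Compound 4 `O=C(/C=C/c1cccnc1)NCCCCCCc1cccc(S(=O)(=O)Nc2ccc(Cl)cc2)c1` has 4-chlorophenyl in place of 3-methylphenyl on a sulfonamide nitrogen. For the measured compounds named here, the only measured step that bears on this change is a 1.7-fold higher number from compound 2 to compound 3 (0.23 log units; within the scatter), which stayed within the scatter. Going by the values given here, no compound with chlorine has been measured yet, so no shift beyond the scatter is expected in this assay. The expected step is a 1.3-fold lower number from compound 3 to compound 4 (0.12 log units; within the scatter). The estimate for compound 4 is 50 nM, with an expected range of 20 nM to 130 nM.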

Compound 4, half-maximal inhibitory concentration: 170 nM
Compound 4: the middle estimate sits 3.4-fold (0.53 log units) below what was measured; the whole stated range lies below it.
By their numbers in this assay, from the lowest: compounds 2 and 3 (each within the scatter of the next); then compound 4; then compound 1.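

In this assay the group on the sulfonamide nitrogen proves sensitive to change: 4-chlorophenyl in place of 3-methylphenyl gives a 2.6-fold higher number from compound 3 to compound 4 (0.41 log units; beyond the scatter) as a modest but real shift. Chloro in place of methyl on an aromatic carbon gives a 4.4-fold higher number from compound 2 to compound 4 (0.64 log units; beyond the scatter) and shows that the identity of the group matters, not only where it sits on the ring. Nothing available explains this shift.

Going by these compounds, it remains open how 3-chlorophenyl would read. Also open, on these data alone, is whether a fluoro or an amine in place of the chloro would restore the lower numbers.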